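The source may hold more compounds than are shown below. What is called first, only, known or untested is meant among the compounds shown, and "the series" means these compounds.

Of the compounds shown here, three built on one shared core have so far been measured in a functional assay on MCF7 cells (Homo sapiens) for antiproliferative activity, read by MTT assay, with a stated time of 48 h; a lower number here means a stronger inhibitor, a higher number a weaker inhibitor. Compound 1 `O=C(Nc1cccc(/C=C/C(=O)c2nc3ccccc3[nH]2)c1)c1cc(Cl)cc(Cl)c1` gives > 100000 nM, which is a limit of the assay rather than a number. Compound 2 `O=C(/C=C/c1cccc(NS(=O)(=O)c2ccccc2Cl)c1)c1nc2ccccc2[nH]1` gives 4280 nM. Compound 3 `Cc1cccc(S(=O)(=O)Nc2cccc(/C=C/C(=O)c3nc4ccccc4[nH]3)c2)c1` gives 886 nM, the lowest of the two numbers in hand. Replacing the carbonyl-linked group on the ring nitrogen by a sulfonyl-linked one brings large steps, an at least 23-fold lower number from compound 1 to compound 2 (1.36 log units; beyond the scatter) and an at least 110-fold lower number from compound 1 to compound 3 (2.05 log units; beyond the scatter), each only a lower bound because of the limit of > 100000 nM in this assay, at which 1 of the 3 values shown sits. Exchanging one aryl ring for another on the sulfonyl sulfur is a more modest step, a 4.8-fold lower number from compound 2 to compound 3 (0.68 log units; beyond the scatter).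

Compound 4 `Cc1cc(C)cc(S(=O)(=O)Nc2cccc(/C=C/C(=O)c3nc4ccccc4[nH]3)c2)c1` has not yet been measured. It differs from compound 3 in one place: methyl in place of hydrogen on an aromatic carbon. Within the data shown here, no measured step exchanges a hydrogen for a methyl, so none bears on it directly; the nearest is a 4.8-fold lower number from compound 2 to compound 3 (0.68 log units; beyond the scatter), which altered the same aryl ring on the sulfonyl sulfur, and a single added methyl is expected to matter less than that. The step of a 1.2-fold lower number from compound 3 to compound 4 (0.07 log units; within the scatter) is therefore expected to stay small, likely within the scatter. Compound 4 is estimated to give about 750 nM, in a range from 250 nM to 2500 nM.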

Compound 4, half-maximal inhibitory concentration: 4570 nM
Compound 4: middle estimate off by 6.1-fold (0.78 log units), on the low side; the measured number lies above the stated range.
By their numbers in this assay, from the lowest: compound 3; then compounds 2 and 4 (each within the scatter of the next). At a limit, above all of these: compound 1.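

In this assay, the position on the aromatic carbon, meta to a methyl group, proves sensitive to a single added methyl (a 5.2-fold higher number from compound 3 to compound 4 (0.71 log units; beyond the scatter)), a step as large as the earlier exchange of one aryl ring for another on the sulfonyl sulfur. Going from 3-methylphenyl to 3,5-dimethylphenyl removes the advantage that compound 3 held over compound 2, since the 3,5-dimethylphenyl and 2-chlorophenyl rings on the sulfonyl sulfur cannot be told apart here (a 1.1-fold higher number from compound 2 to compound 4 (0.03 log units; within the scatter)). Compound 3 alone now stands beyond the scatter from each of the other sulfonyl compounds, and nothing in the data shown accounts for the effect of this second methyl.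

The compounds shown leave open whether any group at this ring carbon raises the number or whether methyl is a special case, a question that a fluorine, a methoxy or an amine in the same place would address. They also leave open how a plain phenyl ring on the sulfonyl sulfur, carrying neither methyl, would compare with compound 3.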